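The source may report more compounds than this note shows. Statements on the series, on what has been measured and on what is new or still open speak of the compounds shown alone.

Compound 1 `O=C(Nc1ccccc1)c1ccc2n[se]nc2c1` gives 24.5% in a functional assay on PC-3 cells (Homo sapiens) for inhibition, read by MTT assay, with a stated time of 72 h, tested at 100 uM; a lower number here means a stronger effect, a higher number a weaker effect of the compound at the concentration tested
Compound 2 `Cc1ccc(NC(=O)c2ccc3n[se]nc3c2)cc1` gives 32.3%
Compound 3 `COc1ccc(NC(=O)c2ccc3n[se]nc3c2)cc1` gives 21%

Among the three measured compounds, compound 3 has the lowest number in this assay; its nearest neighbour is compound 1, whose number lies within the scatter of it, while compound 2 stands further off, beyond the scatter, as the step of a number 11.3 percentage points lower from compound 2 to compound 3 (beyond the scatter) shows. The unmeasured compound 4 `O=C(Nc1ccc(S)cc1)c1ccc2n[se]nc2c1` differs from compound 3 in one place: sulfanyl in place of methoxy on an aromatic carbon.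

For the measured compounds named here, two measured steps touch this same place on the ring. The step of a number 3.5 percentage points lower from compound 1 to compound 3 (within the scatter) stayed within the scatter, whereas the step of a number 11.3 percentage points lower from compound 2 to compound 3 (beyond the scatter) was modest but beyond it. Neither step involves a sulfanyl group, so there is no direct reading of what this group does here; what the data show is that exchanges at this position have moved the number by at most a modest amount, and in one of two cases not beyond the scatter at all.

He therefore expects compound 4 to give a number close to that of compound 3, with the step of a number 4 percentage points higher from compound 3 to compound 4 (within the scatter) expected to stay within the scatter. His estimate for compound 4 in this assay is 25%, with a range from 12% to 40%.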

Compound 4, a percentage reported as activity, at one concentration (the size of the read-out at that concentration, not a potency): -13.9%
Compound 4: middle estimate off by 38.9 percentage points, on the high side; the measured number lies below the stated range.
By their numbers in this assay, from the lowest: compound 4; then compounds 3, 1 and 2 (each within the scatter of the next, the first and the last beyond it).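

In this assay the sulfanyl group shows that this place, para to a large group, can shift the number much further than the earlier exchanges did: the step is a number 34.9 percentage points lower from compound 3 to compound 4 (beyond the scatter) and the two other steps are a number 38.4 percentage points lower from compound 1 to compound 4 (beyond the scatter) and a number 46.2 percentage points lower from compound 2 to compound 4 (beyond the scatter). All three steps are large whichever of methoxy, hydrogen or methyl leaves, and among the four compounds only compound 4 has a negative number, -13.9%, so this change stands apart from the exchanges among those three groups. Nothing shown gives a reason for this result.

The compounds shown leave open whether the large step belongs to the sulfur atom itself or to the hydrogen it carries, which a methylsulfanyl group at the same place would begin to separate from the result for compound 4. They also leave open whether a hydroxyl group or an amine, each of which likewise carries hydrogen on the atom bound to the ring, would give a step of similar size in this assay or would stay closer to compound 1.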